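Swapping a pyrazole for a pyrrole on a shared core

The compounds below may be only part of what the source reports. "The series", "measured", "known", "first", "only" and "open" are said of these compounds alone.

Three measured compounds share one core and differ only in the five-membered heteroaromatic ring attached to it. Compound 1 `c1ccc(-c2nc[nH]n2)c(NCC2=NCCN2)c1` gives 3.98 nM in an in vitro functional assay on cells (Fibroblast) for agonist activity at Alpha-1D adrenergic receptor (Homo sapiens); a higher number here means that more compound is needed for the effect, a lower number that less compound is needed. Compound 2 `Cn1ncnc1-c1ccccc1NCC1=NCCN1` gives 63.1 nM in this assay, which amounts to a 16-fold higher number from compound 1 to compound 2 (1.20 log units; beyond the scatter). For compound 3 `Cn1cc(-c2ccccc2NCC2=NCCN2)cn1` only a limit, not a number, is known in this assay, namely < 100000 nM. Compound 3 therefore stands at the limit of < 100000 nM in this assay, at which 1 of the 3 values shown sits, so the steps a step that the limit leaves unreadable from compound 1 to compound 3 and a step that the limit leaves unreadable from compound 2 to compound 3 have no readable size.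

Compound 4 `Cn1cccc1-c1ccccc1NCC1=NCCN1` carries the change (1-methyl-1H-pyrrol-2-yl in place of 1-methyl-1H-pyrazol-4-yl on an aromatic carbon). Going by the values given here, the only readable step, a 16-fold higher number from compound 1 to compound 2 (1.20 log units; beyond the scatter), shows that altering this ring can move the result strongly, while the two steps into compound 3 give no size at all, so the change to compound 4 rests on a weak footing. The step that the limit leaves unreadable from compound 3 to compound 4 is the expected outcome, with wide uncertainty. Compound 4 is expected to give 3000 nM in this assay, within a range from 150 nM to 60000 nM.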

Compound 4, half-maximal effective concentration: 251 nM
The estimate for compound 4 lay 12-fold (1.08 log units) above the measured number; low and high end bracket the measured number.
By their numbers in this assay, from the lowest: compound 1; then compound 2; then compound 4.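

In this assay, the 1-methyl-1H-pyrrol-2-yl group of compound 4 gives a readable number at this position on the ring, so a ring with a single hetero atom can still give agonist activity here. Among the readable compounds, it shows a 4.0-fold higher number from compound 2 to compound 4 (0.60 log units; beyond the scatter) and a 63-fold higher number from compound 1 to compound 4 (1.80 log units; beyond the scatter), which leaves compound 1 with the lowest number of the three. The step from compound 3 to compound 4 and the other steps into compound 3 cannot be read: the limit of < 100000 nM in this assay, at which 1 of the 4 values shown sits.

1-methyl-1H-pyrazol-4-yl and 1-methyl-1H-pyrrol-2-yl differ in both their ring atoms and their point of attachment, and the compounds shown do not separate these two changes. As far as these compounds go, it also remains open what a 1H-pyrrol-2-yl ring without the methyl group, or one carrying an amine, would give.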